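Chloro substitution on the phenyl arm of compound 3

The source may report more compounds than this note shows. Statements on the series, on what has been measured and on what is new or still open speak of the compounds shown alone.

Measured so far in a toxicity assay on HeLa cells (Homo sapiens) for cytotoxicity, read by MTT assay, with a stated time of 24 h; a lower number here means a stronger inhibitor, a higher number a weaker inhibitor:
Compound 1 `CCN1CCN(C(=S)SCC(O)Cn2cc([N+](=O)[O-])nc2C)CC1` sits at a limit of the assay, > 5000000 nM.
Compound 2 `CCOC(=O)N1CCN(C(=S)SCC(O)Cn2cc([N+](=O)[O-])nc2C)CC1` gives 2360000 nM.
Compound 3 `Cc1nc([N+](=O)[O-])cn1CC(O)CSC(=S)N1CCN(c2ccccc2)CC1` sits at a limit of the assay, > 5000000 nM.

Compound 3 thus stands at the limit shared by two of the three values (the limit of > 5000000 nM in this assay, at which 2 of the 3 values shown sit); only compound 2 gives a number, and the step of an at least 2.1-fold higher number from compound 2 to compound 3 (0.32 log units; beyond the scatter) is read from that number against the limit. Compound 4 `Cc1nc([N+](=O)[O-])cn1CC(O)CSC(=S)N1CCN(c2cccc(Cl)c2)CC1` differs from compound 3 by chloro in place of hydrogen on an aromatic carbon. For the measured compounds named here, none of the measured steps touches the phenyl arm: an at least 2.1-fold lower number from compound 1 to compound 2 (0.32 log units; beyond the scatter) and a step that the two limits leave unreadable from compound 1 to compound 3 each swap the whole group on the ring nitrogen. Nothing measured therefore bears on this change, and no step beyond the scatter is expected in this assay. Compound 4 is expected to remain at the limit, estimated at 5000000 nM (range 2000000 nM to 12000000 nM), with the expected step of a number no higher from compound 3 to compound 4 (the limit leaves the size open) being essentially none.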

Compound 4, half-maximal inhibitory concentration: 1740000 nM
The estimate for compound 4 lay 2.9-fold (0.46 log units) above the measured number; measured number outside the range, below it.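

Chloro in place of hydrogen on the phenyl arm is the first change at this position, and in this assay it gives an at least 2.8-fold lower number from compound 3 to compound 4 (0.45 log units; beyond the scatter), so the arm is not silent. Against the ethyl group the 3-chlorophenyl group gives an at least 2.8-fold lower number from compound 1 to compound 4 (0.45 log units; beyond the scatter), while against ethoxycarbonyl it gives a 1.4-fold lower number from compound 2 to compound 4 (0.13 log units; within the scatter), which separates neither group from the other. The first two sizes are minimums only, because compound 1 and compound 3 each sit at a limit: the limit of > 5000000 nM in this assay, at which 2 of the 4 values shown sit.

Open, as far as these compounds go, is whether the gain belongs to chloro itself, as fluoro, bromo, methyl or methoxy in the same place would show. Also open, from the compounds shown here alone, is how chloro behaves elsewhere on the phenyl ring.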